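Aryl exchange from compound 3 to compound 4

The compounds below may be only part of what the source reports. "The series", "measured", "known", "first", "only" and "open" are said of these compounds alone.

Values in a functional assay on G-361 cells (Homo sapiens) for inhibition, with a stated time of 72 h; a higher number here means a weaker inhibitor, a lower number a stronger inhibitor:
- compound 1 `NC1CCC(Nc2nc(NCc3ccc(-c4ccccc4)cc3)c3ncn(C4CCCC4)c3n2)CC1`: 1020 nM
- compound 2 `NC1CCC(Nc2nc(NCc3ccc(-c4ccsc4)cc3)c3ncn(C4CCCC4)c3n2)CC1`: 570 nM
- compound 3 `NC1CCC(Nc2nc(NCc3ccc(-c4cccc(F)c4)nc3)c3ncn(C4CCCC4)c3n2)CC1`: 49 nM

Compound 3, at 49 nM, has the lowest number of the three. Its gaps to compound 2 at 570 nM and to compound 1 at 1020 nM both lie beyond the scatter.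

Compound 4 `NC1CCC(Nc2nc(NCc3ccc(-c4cccs4)nc3)c3ncn(C4CCCC4)c3n2)CC1` carries thiophen-2-yl in place of 3-fluorophenyl on an aromatic carbon, next to the ring nitrogen and para to a large group (thiophen-2-yl in place of 3-fluorophenyl on an aromatic carbon).

For the measured compounds named here, only one measured step bears on this change: a 1.8-fold lower number from compound 1 to compound 2 (0.25 log units; within the scatter), with thiophen-3-yl in place of phenyl, which lies within the scatter. That step involves neither thiophen-2-yl nor 3-fluorophenyl, and compound 1 and compound 2 lack the ring nitrogen of compound 3, so it transfers only loosely. In this assay, no step beyond the scatter is expected, with a slight lean towards a higher number. The estimated step is a 1.2-fold higher number from compound 3 to compound 4 (0.09 log units; within the scatter). Compound 4 is expected at 60 nM, with an estimated range of 20 nM to 180 nM.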

Compound 4, half-maximal inhibitory concentration: 150 nM
Beside the measured number, compound 4's estimate is 2.5-fold (0.40 log units) below it, and the stated range covers the measured number.
By their numbers in this assay, from the lowest: compound 3; then compound 4; then compounds 2 and 1 (each within the scatter of the next).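

For the compounds shown here, at this aromatic carbon, next to the ring nitrogen and para to a large group, the choice of aryl group registers in this assay: thiophen-2-yl in place of 3-fluorophenyl gives a 3.1-fold higher number from compound 3 to compound 4 (0.49 log units; beyond the scatter), whereas the only earlier aryl exchange, on the ring without nitrogen, gave a 1.8-fold lower number from compound 1 to compound 2 (0.25 log units; within the scatter) and stayed within the scatter. The thiophen-2-yl compound still keeps an advantage over the biaryl groups without ring nitrogen, with a 3.8-fold lower number from compound 2 to compound 4 (0.58 log units; beyond the scatter) and a 6.8-fold lower number from compound 1 to compound 4 (0.83 log units; beyond the scatter). Nothing available explains the size of these steps.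

As far as these compounds go, those last two steps change the ring nitrogen and the outer aryl group together, so the share of each remains open. Also open, from the compounds shown here alone, is how a phenyl ring carrying an amine or a carboxylic acid would read at this carbon.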